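A Carbonyl Step From Compound 1 to Compound 3

The source may hold more compounds than are shown below. What is called first, only, known or untested is meant among the compounds shown, and "the series" means these compounds.

Compound 1 (`O=C(NNc1ccc(F)cc1)c1cccc(NS(=O)(=O)c2cnc(O)nc2O)c1`) stands at the edge of what a functional assay on A549 cells (Homo sapiens) for antiproliferative activity, read by MTT assay, with a stated time of 24 h (on this read-out higher numbers stand for weaker inhibition and lower numbers for stronger inhibition), can report. In that assay compound 1 gives > 20000 nM as its result, which is a limit and not a number. Compound 2 (`O=C(NNC(=O)c1ccc(NS(=O)(=O)c2cnc(O)nc2O)cc1)c1ccc(F)cc1`) gives > 20000 nM in this assay and is likewise recorded only as a limit. Among the measured compounds shown here, no number has therefore been measured in this small set, and no step between measured compounds is available.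

Compound 3 (`O=C(NNC(=O)c1cccc(NS(=O)(=O)c2cnc(O)nc2O)c1)c1cccc(Cl)c1`) is reached from compound 1 by placing (3-chlorophenyl)carbonyl in place of 4-fluorophenyl on an amine nitrogen. The shared core stays as it is.

The only ground for an expectation comes from compound 1 and compound 2, namely the limit of > 20000 nM in this assay, at which 2 of the 2 values shown sit, and no measured activity beyond it. The expected step that the limit leaves unreadable from compound 1 to compound 3 is therefore no change beyond the scatter in either direction. In this assay the estimate for compound 3 is 25000 nM with an expected range from 8000 nM to 60000 nM and a good chance of only a limit.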

Compound 3, half-maximal inhibitory concentration: 6000 nM
For compound 3 the middle estimate is 4.2-fold (0.62 log units) above the measured one; measured number outside the range, below it.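

In this assay, the amine nitrogen proves to be a place where a single change brings a measurable reading into this set: putting (3-chlorophenyl)carbonyl in place of 4-fluorophenyl gives an at least 3.3-fold lower number from compound 1 to compound 3 (0.52 log units; beyond the scatter). Compound 1 stands at > 20000 nM, which is a limit of the assay and not a number, so the step has a smallest size but no known full size. Compound 3 is the only compound shown with a number, and the other readings stay at the edge of the assay: the limit of > 20000 nM in this assay, at which 2 of the 3 values shown sit.

The change brings in a carbonyl and also replaces a fluorine-bearing ring with a chlorine-bearing one, and the compounds shown do not tell which of these two differences carries the step. As far as these compounds go, on the core of compound 1, it remains open how 3-chlorophenyl without the carbonyl, (4-fluorophenyl)carbonyl or a plain acetyl on the same amine nitrogen would read in this assay.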